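Sulfonyl swap in a series held at its limit

A few compounds are considered here, and "the series" means these few. Any claim that something is new, unique, unknown or untested is made for them only; others in the source may bear on it.

Measured so far in a functional assay on SEM cells (Homo sapiens) for cytotoxicity, with a stated time of 72 h; a higher number here means that more compound is needed for the effect, a lower number that less compound is needed:
Compound 1 `C=C[C@@](C)(/C=C/c1ccc(OCc2ccccc2)cc1)CCC=C(C)C` gives > 36600 nM (a limit)
Compound 2 `C=C[C@@](C)(/C=C/c1ccc(OS(=O)(=O)C(F)(F)F)cc1)CCC=C(C)C` gives > 36600 nM (a limit)

Compound 2 stands at > 36600 nM as a limit only, with no number to start from. Compound 3 `C=C[C@@](C)(/C=C/c1ccc(OS(=O)(=O)c2ccc(C)cc2)cc1)CCC=C(C)C` is next, and the change from compound 2 is 4-methylphenyl in place of trifluoromethyl on a sulfonyl sulfur on a sulfonyl sulfur. Within the data shown here, the only measured step bearing on it is a step that the two limits leave unreadable from compound 1 to compound 2 and gives no size or direction. Among the measured compounds shown here, the series so far offers only the limit of > 36600 nM in this assay, at which 2 of the 2 values shown sit, as its evidence. Hence no step of known size or direction is expected in this assay, and the estimated a number no higher from compound 2 to compound 3 (the limit leaves the size open) is tentative. For compound 3 the expected value is 36600 nM within an estimated range of 12000 nM to 80000 nM as a working figure.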

Compound 3, half-maximal effective concentration: > 43400 nM
Compound 3: no number, only a limit (the forecaster's own chance of this, stated with the estimate: 75%); at least 1.1-fold (0.07 log units) between middle value and limit.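

In this assay compound 2 and compound 3 are both held at limits, so the step between them, 4-methylphenyl in place of trifluoromethyl, cannot be read. The compounds shown leave open whether any substituent on this oxygen gives a real number in this assay.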